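This account rests on a few compounds, and the source may have more. Where it says the series, first, only, none or still open, it means among the compounds named here.

Compound 1 `Cc1ccccc1OCCCO`: 2.34
Compound 2 `Cc1cc(OCCCO)cc(C)c1Cl`: 3.38
Compound 3 `Cc1cccc(Cl)c1OCCCO`: 2.93

In a physicochemical assay for lipophilicity, measured as octanol-water partition (a lower number here means a more polar compound, a higher number a more lipophilic compound), compound 1 has the lowest of the three numbers at 2.34, with compound 3 nearest and compound 2 furthest away. Compound 4 `Cc1ccccc1OCC(C)O` has the same atoms as compound 1, joined differently: 1-hydroxyethyl in place of 2-hydroxyethyl on a saturated chain carbon bound to an oxygen on an aromatic ring. Cut one bond further out, 3-hydroxypropyl gives way to 2-hydroxypropyl. For the measured compounds named here, the only measured step, a number 0.59 log units higher from compound 1 to compound 3 (beyond the scatter), is modest and comes from chloro in place of hydrogen on an aromatic carbon, a different kind of change. Going by the values given here, no measured step covers this rearrangement. A smaller step than that one is expected, within the scatter and without a firm direction. The estimated step is a number 0.06 log units higher from compound 1 to compound 4 (within the scatter). Compound 4 is expected at 2.4, with an estimated range from 2.1 to 2.7.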

Compound 4, partition coefficient: 2.14
Beside the measured number, compound 4's estimate is 0.26 log units above it; measured number inside the range.
By their numbers in this assay, from the lowest: compounds 4 and 1 (each within the scatter of the next); then compound 3; then compound 2.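

At this place, on a saturated chain carbon bound to an oxygen on an aromatic ring, 1-hydroxyethyl in place of 2-hydroxyethyl gives a number 0.20 log units lower from compound 1 to compound 4 (within the scatter) in this assay. The two isomeric chains therefore cannot be told apart in this measurement, whereas the chloro change gives a number 0.59 log units higher from compound 1 to compound 3 (beyond the scatter) and does stand clear of the scatter.

From the compounds shown here alone, it remains open whether the same chain change would read alike on the chloro-bearing core of compound 3, or whether an amine in place of the hydroxyl would step beyond the scatter. No supporting data bear on this step, so nothing explains it.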